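This account rests on a few compounds, and the source may have more. Where it says the series, first, only, none or still open, it means among the compounds named here.

Measured so far:
compound 1 `CC1CC(C(=O)N2CCc3nc(C#Cc4ccccc4)sc3C2)C1` — in an assay on HEK293 cells for negative allosteric modulation of metabotropic glutamate receptor 5 (Homo sapiens), read by FLIPR, with a stated time of 1 h (on this read-out lower numbers stand for stronger inhibition and higher numbers for weaker inhibition), compound 1 gives > 10000 nM, which is a limit of the assay.
compound 2 `O=C(C1CCOCC1)N1CCc2nc(C#Cc3ccccc3)sc2C1` — in this assay compound 2 gives > 10000 nM, also a limit.
compound 3 `O=C(C1CCCCO1)N1CCc2nc(C#Cc3ccccc3)sc2C1` — in this assay compound 3 gives > 10000 nM, again a limit.

Compound 3 therefore stands at a limit rather than at a number, and the two other values shown are limits as well (the limit of > 10000 nM in this assay, at which 3 of the 3 values shown sit). Compound 4 `O=C(N1CCC(F)CC1)N1CCc2nc(C#Cc3ccccc3)sc2C1` differs from compound 3 in one place: 4-fluoropiperidin-1-yl in place of oxan-2-yl on a carbonyl carbon. The measured steps that touch this carbonyl position all run between limits and so cannot be sized: a step that the two limits leave unreadable from compound 1 to compound 2, a step that the two limits leave unreadable from compound 1 to compound 3 and a step that the two limits leave unreadable from compound 2 to compound 3. Going by the values given here, no step among the three compounds gives a readable direction or magnitude, so the expectation for compound 4 rests only on the fact that every compound so far sits at the limit. Compound 4 is expected to remain weak, with an estimated 10000 nM and a range from 3000 nM to 30000 nM. The corresponding expected step of a number no higher from compound 3 to compound 4 (the limit leaves the size open) is thus estimated to be none beyond the scatter.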

Compound 4, half-maximal inhibitory concentration: > 10000 nM
Compound 4 ended at the assay's limit (the forecaster's own chance of this, stated with the estimate: 70%); the middle value sits exactly at the limit.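

The steps from compound 1, compound 2 and compound 3 to compound 4 cannot be read, as all of these values are limits and not numbers: the limit of > 10000 nM in this assay, at which 4 of the 4 values shown sit.

The compounds shown leave open what value lies behind each limit, and whether any group on the carbonyl carbon would give a measurable number in this assay.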